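The source may hold more compounds than are shown below. What is called first, only, known or untested is meant among the compounds shown, and "the series" means these compounds.

The measured compounds are compound 1, `COc1c(NS(=O)(=O)c2ccc(F)cc2)cc(-c2ccc3nc(NC4CC4)sc3n2)cc1C(N)=O`, which in a functional assay on A549 cells (Homo sapiens) for antiproliferative activity, read by MTT assay, with a stated time of 72 h (on this read-out higher numbers stand for weaker inhibition and lower numbers for stronger inhibition), gives 30300 nM, and compound 2, `COc1c(NS(=O)(=O)c2ccc(F)cc2)cc(-c2ccc3nc(NC(=O)C4CC4)sc3n2)cc1C(N)=O`, which in this assay gives 8050 nM. Compound 3, `COc1c(NS(=O)(=O)c2ccc(F)cc2)cc(-c2ccc3nc(NC4CC4)sc3c2)cc1C(N)=O`, has no result reported in this assay, where compound 3 stands as "not determined" (no result reported).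

From compound 1 to compound 2 the change is cyclopropylcarbonyl in place of cyclopropyl on a nitrogen on an aromatic ring, and it made the step of a 3.8-fold lower number from compound 1 to compound 2 (0.58 log units; beyond the scatter). Compound 4, `COc1c(NS(=O)(=O)c2ccc(F)cc2)cc(-c2ccc3nc(NC(=O)C4CC4)sc3c2)cc1C(N)=O`, carries the same change relative to compound 3: cyclopropylcarbonyl in place of cyclopropyl on a nitrogen on an aromatic ring. The difference between the two cores is not broken down here. The place of the change is described in the same words for both pairs; this counts as the same change. Among the compounds with values here, compound 3 has no measured value, so there is no anchor for a step, and the expectation rests only on the step of a 3.8-fold lower number from compound 1 to compound 2 (0.58 log units; beyond the scatter) and on compound 2 at 8050 nM. Compound 4 is expected to lie near 10000 nM, with a wide estimated range from 2000 nM to 50000 nM.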

Compound 4, half-maximal inhibitory concentration: 6340 nM
For compound 4 the middle estimate is 1.6-fold (0.20 log units) above the measured one; the measured number falls inside the stated range.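

No step can be read from compound 3 to compound 4, as compound 3 has no number in this assay. Going by these compounds, whether cyclopropylcarbonyl in place of cyclopropyl shifts the value on this core as it does on the core of compound 1 stays open. No evidence here bears on the result.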